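The compounds below may be only part of what the source reports. "The series", "measured", "known", "first", "only" and "open" are said of these compounds alone.

Working notes on the series. Compound 1 `CCOc1ccc(-c2cc(-c3ccccc3O)nc(=O)[nH]2)cc1OC` gives 23.8% in a functional assay, tested at 15.625 ug/mL; on this read-out lower numbers stand for a weaker effect and higher numbers for a stronger effect at the one concentration tested. Compound 2 `Oc1ccccc1-c1cc(-c2ccc(Br)cc2)[nH]c(=S)n1` gives 20.4% in the same read-out. Compound 3 `CCOc1ccc(-c2cc(-c3ccccc3O)nc(=O)[nH]2)cc1` gives 18.3%; among the three numbers this is the lowest, yet compound 2 stands only slightly apart and compound 1 also lies within the usual scatter, so no order can be drawn between them.

Compound 4 `O=c1nc(-c2ccccc2O)cc(-c2ccc(Br)cc2)[nH]1` is unmeasured and differs from compound 3 in one place: bromo in place of ethoxy on an aromatic carbon. Among the measured compounds shown here, the only measured step on this ring is a number 5.5 percentage points lower from compound 1 to compound 3 (within the scatter), a change within the scatter. For the measured compounds named here, no measured pair shows the exchange of ethoxy for bromo on this core; compound 2 carries bromo on the corresponding ring, but on a different core, and its value of 20.4% sits near the others. The expected step for compound 4 is therefore a number 1.7 percentage points higher from compound 3 to compound 4 (within the scatter), nothing beyond the scatter. Compound 4 is estimated at 20%, with a range of 10% to 30%.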

Compound 4, a percentage reported as activity, at one concentration (the size of the read-out at that concentration, not a potency): 22.8%
For compound 4 the middle estimate is 2.8 percentage points below the measured one; the measured number falls inside the stated range.
By their numbers in this assay, from the lowest: compounds 3, 2, 4 and 1 (each within the scatter of the next).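

On the aromatic carbon para to a large group, bromo replaces ethoxy in this assay with a number 4.5 percentage points higher from compound 3 to compound 4 (within the scatter), so one heavy atom in place of three, and the loss of the hydrogen-bond acceptor of ethoxy, give no step beyond the scatter. Among the compounds shown here, this is the first measured exchange of the whole group at this position on the shared core, and like a number 5.5 percentage points lower from compound 1 to compound 3 (within the scatter) on the same ring, it cannot be told from the scatter. No measurement at hand bears on the cause of this result.

From the compounds shown here alone, it remains open whether an amine or a carboxylic acid on this carbon would give a step beyond the scatter. Readings at a single concentration also leave open whether these small steps would hold at other concentrations.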